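The source may report more compounds than this note shows. Statements on the series, on what has been measured and on what is new or still open speak of the compounds shown alone.

Among the measured compounds shown here, in a functional assay on HepG2 cells (Homo sapiens) for inhibition, with a stated time of 72 h (a higher number here means a weaker inhibitor, a lower number a stronger inhibitor), three compounds built on a shared core have numbers so far. Compound 1 (`COc1ccc(NC(=O)Nc2nc(Sc3c[nH]c4ccccc34)cc(N3CCCCC3)n2)cc1`) gives 17100 nM, compound 2 (`O=C(Nc1ccccc1)Nc1nc(NC2CC2)cc(Sc2c[nH]c3ccccc23)n1`) gives 14300 nM and compound 3 (`O=C(Nc1ccccc1)Nc1nc(Nc2ccc(Cl)cc2)cc(Sc2c[nH]c3ccccc23)n1`) gives 12600 nM, which places compound 3 within the scatter of both others. The account now moves to compound 4 (`O=C(Nc1ccccc1)Nc1nc(Sc2c[nH]c3ccccc23)cc(N2CCCCC2)n1`), with piperidin-1-yl in place of (4-chlorophenyl)amino on an aromatic carbon. For the measured compounds named here, the one measured step that bears on this change is a 1.1-fold lower number from compound 2 to compound 3 (0.05 log units; within the scatter), with 4-chlorophenyl in place of cyclopropyl on a nitrogen on an aromatic ring, and it lies within the scatter. Compound 1 also carries piperidin-1-yl, and its 17100 nM lies within the scatter of compound 3. No step beyond the scatter is therefore expected in this assay, and the data favour no clear direction. The expected step, a 1.2-fold higher number from compound 3 to compound 4 (0.08 log units; within the scatter), is an estimate that stays within the scatter. For compound 4 the estimated value is 15000 nM, with an expected range from 7500 nM to 30000 nM.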

Compound 4, half-maximal inhibitory concentration: 20900 nM
Compound 4: the middle estimate sits 1.4-fold (0.14 log units) below what was measured; the range from low to high includes it.
By their numbers in this assay, from the lowest: compounds 3, 2, 1 and 4 (each within the scatter of the next).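

In (this assay), piperidin-1-yl on this aromatic carbon in place of (4-chlorophenyl)amino gives a step within the scatter (a 1.7-fold higher number from compound 3 to compound 4 (0.22 log units; within the scatter)), and in place of cyclopropylamino it also gives a step within the scatter (a 1.5-fold higher number from compound 2 to compound 4 (0.16 log units; within the scatter)). Among the compounds shown here, the position thus takes a non-aromatic ring bound through its nitrogen, with no hydrogen-bond donor, without a step beyond the scatter, which the earlier compounds could not show through a direct comparison with compound 3 on the phenyl side. With piperidin-1-yl held in place, hydrogen in place of methoxy also stays within the scatter (a 1.2-fold higher number from compound 1 to compound 4 (0.09 log units; within the scatter)), and nothing available explains any of these steps. As far as these compounds go, whether a morpholine, a primary amine or a carboxylic acid at this position would move the number beyond the scatter remains open. So does the effect of changing the (1H-indol-3-yl)sulfanyl group.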